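A Methyl on the Piperazine of Compound 2

This account rests on a few compounds, and the source may have more. Where it says the series, first, only, none or still open, it means among the compounds named here.

Compound 1 `CC(C)(C)c1ccc2[nH]c(N3CCN(c4ncccc4Cl)CC3)nc2c1` gives 1690 nM in a functional assay on HEK293 cells for antagonist activity at transient receptor potential cation channel subfamily V member 1 (Homo sapiens), read by FLIPR, at pH 5.5; a higher number here means a weaker inhibitor, a lower number a stronger inhibitor. Compound 2 `CC(C)(C)c1ccc2oc(N3CCN(c4ncccc4Cl)CC3)nc2c1` differs in its core and reaches only a limit of this assay, > 10000 nM. Compound 2 therefore stands at the limit of > 10000 nM in this assay, at which 1 of the 2 values shown sits, the less potent end of the two numbers shown, and no exact value is known for it. Compound 3 `C[C@@H]1CN(c2ncccc2Cl)CCN1c1nc2cc(C(C)(C)C)ccc2o1` is the next compound, built from compound 2 by the change (methyl in place of hydrogen on a saturated ring carbon). For the measured compounds named here, since no measured pair shows the effect of such a methyl, the size of this step is open. Compound 3 is expected to give 7000 nM in this assay, within 2000 nM to 20000 nM. The expected step of an at least 1.4-fold lower number from compound 2 to compound 3 (0.15 log units; that floor lies within the scatter) is toward somewhat stronger inhibition, though it may still fall within the scatter or end at the limit again.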

Compound 3, half-maximal inhibitory concentration: 1410 nM
Compound 3: middle estimate off by 5.0-fold (0.70 log units), on the high side, outside the stated range (below it).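

Set on a saturated ring carbon next to the ring nitrogen, a single methyl takes the compound off the limit in this assay, with an at least 7.0-fold lower number from compound 2 to compound 3 (0.85 log units; beyond the scatter). The earlier compounds shown here gave no view of this ring carbon, and this pair shows that it accepts a methyl and that the change here goes toward stronger inhibition. The true size of the step stays unknown, and the printed figure is only a floor, because compound 2 carries a limit and no exact value: the limit of > 10000 nM in this assay, at which 1 of the 3 values shown sits.

As far as these compounds go, whether a longer chain such as ethyl, or a hydroxymethyl, on this same carbon would give a similar step remains open. Also open, from the compounds shown here alone, is whether the methyl acts in the same way on the core of compound 1, and what the opposite configuration at this carbon would give.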